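The source may report more compounds than this note shows. Statements on the series, on what has been measured and on what is new or still open speak of the compounds shown alone.

Measured so far:
compound 1, `Fc1ccc(/C=C\c2cc3ccccc3nc2Cl)cc1`, 20300 nM in a functional assay on MCF7 cells (Homo sapiens) for antiproliferative activity, read by sulforhodamine B assay, with a stated time of 72 h; on this read-out higher numbers stand for weaker inhibition and lower numbers for stronger inhibition
compound 2, `COc1ccc2nc(Cl)c(/C=C\c3ccc(F)cc3)cc2c1`, 8970 nM
compound 3, `FC(F)(F)c1ccc(/C=C\c2cc3ccccc3nc2Cl)c(C(F)(F)F)c1`, 10500 nM

Compound 2 differs from compound 1 by one change, (methoxy in place of hydrogen on an aromatic carbon), and this change brought a 2.3-fold lower number from compound 1 to compound 2 (0.35 log units; beyond the scatter) in this assay. Compound 3 and compound 1 carry different groups on the other end of the molecule; the difference between these two cores is not broken down here, and their two values lie within the scatter of each other.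

Compound 4, `COc1ccc2nc(Cl)c(/C=C\c3ccc(C(F)(F)F)cc3C(F)(F)F)cc2c1`, is not yet measured. Going by the values given here, it differs from compound 3 by methoxy in place of hydrogen on an aromatic carbon, which is the same change as the one from compound 1 to compound 2. Resting on that earlier step, the expectation for compound 4 in this assay is a step of about a 2.3-fold lower number from compound 3 to compound 4 (0.36 log units; beyond the scatter), a similar size. Compound 4 is therefore estimated at 4600 nM, with a likely range from 2000 nM to 11000 nM.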

Compound 4, half-maximal inhibitory concentration: > 50000 nM
Compound 4: a limit, no number; the forecaster's own chance of this, stated with the estimate: 5%; middle value at least 10-fold (1.03 log units) from the limit.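

The same methoxy change gave an at least 4.7-fold higher number from compound 3 to compound 4 (0.67 log units; beyond the scatter) in this assay, so it did not carry over from the core of compound 1 to the core of compound 3, and the two steps do not agree: the same change on two cores in this assay, a 2.3-fold lower number (0.35 log units; beyond the scatter) from compound 1 to compound 2 and an at least 4.7-fold higher number (0.67 log units; beyond the scatter) from compound 3 to compound 4, at least 10-fold (1.03 log units) apart, beyond the scatter of two such steps

Compound 4 reads > 50000 nM, which is a limit of the assay and not a number.

On these data alone, the true size of this step therefore stays unknown, and two pairs cannot show why the steps part or how the change would behave on any further core.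

As far as these compounds go, it remains open whether methoxy would lower or raise the number with a single trifluoromethyl group in place of the two in compound 3, and what an amine or a longer ether chain would do in place of methoxy.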